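Swapping pyridin-2-yl for methyl(phenyl)amino on the sulfonyl sulfur

The source may hold more compounds than are shown below. What is called first, only, known or untested is meant among the compounds shown, and "the series" means these compounds.

Measured in a functional assay on J774 cells (Mus musculus) for cytotoxicity (on this read-out higher numbers stand for weaker inhibition and lower numbers for stronger inhibition), the three compounds read as follows.
Compound 1 `CCCN(CCC)c1c([N+](=O)[O-])cc(S(=O)(=O)Nc2cccc(Cl)c2)cc1[N+](=O)[O-]` gives 8700 nM
Compound 2 `CCCN(CCC)c1c([N+](=O)[O-])cc(S(=O)(=O)Nc2ccc(Cl)c(Cl)c2)cc1[N+](=O)[O-]` gives 7200 nM
Compound 3 `CCCN(CCC)c1c([N+](=O)[O-])cc(S(=O)(=O)Nc2ccccn2)cc1[N+](=O)[O-]` gives 45000 nM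

Compound 3 stands highest of the three on these numbers. Compound 4 `CCCN(CCC)c1c([N+](=O)[O-])cc(S(=O)(=O)N(C)c2ccccc2)cc1[N+](=O)[O-]` differs from it by one change (methyl(phenyl)amino in place of (pyridin-2-yl)amino on a sulfonyl sulfur), with methyl(phenyl)amino in place of (pyridin-2-yl)amino on a sulfonyl sulfur. For the measured compounds named here, two measured steps bear on this: a 5.2-fold higher number from compound 1 to compound 3 (0.71 log units; beyond the scatter) and a 6.3-fold higher number from compound 2 to compound 3 (0.80 log units; beyond the scatter) are both modest. By contrast, a 1.2-fold lower number from compound 1 to compound 2 (0.08 log units; within the scatter) stays within the scatter. Going by the values given here, no measured compound carries a methyl on the sulfonamide nitrogen, so the expectation is loose. A modest move to a lower number is expected (a 3.0-fold lower number from compound 3 to compound 4 (0.48 log units; beyond the scatter)). Compound 4 is estimated at 15000 nM (expected range 5000 nM to 45000 nM).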

Compound 4, half-maximal inhibitory concentration: 11000 nM
The estimate for compound 4 lay 1.4-fold (0.13 log units) above the measured number, and the stated range covers the measured number.
By their numbers in this assay, from the lowest: compounds 2, 1 and 4 (each within the scatter of the next); then compound 3.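

In this assay, methyl(phenyl)amino on the sulfonyl sulfur gives a 4.1-fold lower number from compound 3 to compound 4 (0.61 log units; beyond the scatter) and so leaves the high number of the (pyridin-2-yl)amino compound behind. Compound 4 has no chloro group and no hydrogen-bond donor in this group, yet it sits level with the chlorinated compounds: a 1.5-fold higher number from compound 2 to compound 4 (0.18 log units; within the scatter) and a 1.3-fold higher number from compound 1 to compound 4 (0.10 log units; within the scatter) both stay within the scatter. Nothing at hand accounts for these readings. The compounds shown do not separate the added methyl from the loss of the ring nitrogen, and an ethyl on the sulfonamide nitrogen remains open.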